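Removing the propyl group from compound 1

The source may hold more compounds than are shown below. What is called first, only, known or untested is meant among the compounds shown, and "the series" means these compounds.

In a functional assay on K562 cells (Homo sapiens) for antiproliferative activity, read by CCK-8 assay, with a stated time of 72 h (on this read-out higher numbers stand for weaker inhibition of growth and lower numbers for stronger inhibition of growth), compound 1 `CCCNC(=O)c1ccc2c(ccn2-c2ncc3c(n2)N(c2ccn(C)n2)C(CC)C(=O)N3C)c1` gives 8270 nM as the higher of the two numbers available. Compound 2 `CC[C@@H]1C(=O)N(C)c2cnc(-n3ccc4cc(C(=O)NC(C)C)ccc43)nc2N1C1CCCC1` gives 786 nM in the same test, a lower number by a margin well beyond the usual scatter. These two compounds differ in more than one place, so their gap cannot be tied to any single change. Compound 3 `CCC1C(=O)N(C)c2cnc(-n3ccc4cc(C(N)=O)ccc43)nc2N1c1ccn(C)n1` departs from compound 1 in one place only: hydrogen in place of propyl on an amide-type nitrogen with hydrogen in place of propyl on an amide-type nitrogen. Among the measured compounds shown here, no measured pair shows what this change does in this assay and the expectation is therefore loose. A modest move toward a lower number is expected, and the estimated change is a 2.4-fold lower number from compound 1 to compound 3 (0.37 log units; beyond the scatter) in this direction. Compound 3 is estimated at 3500 nM with an expected range from 900 nM to 12000 nM in this test.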

Compound 3, concentration for 50% growth inhibition: 31300 nM
For compound 3 the middle estimate is 8.9-fold (0.95 log units) below the measured one, and the stated range ends below it.
By their numbers in this assay, from the lowest: compound 2; then compound 1; then compound 3.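

In this assay, replacing propyl with hydrogen on the amide-type nitrogen gives a 3.8-fold higher number from compound 1 to compound 3 (0.58 log units; beyond the scatter), a move towards weaker inhibition of growth. This single-place step shows that growth inhibition in this test is sensitive to the substituent on this nitrogen, and that, of these two compounds, the propylcarbamoyl group of compound 1 goes with the stronger inhibition and the plain carbamoyl group of compound 3 with the weaker. No measurement shown here bears on why the step runs this way.

With only hydrogen and propyl compared on this core, the compounds shown do not tell whether a shorter chain such as methyl or ethyl would fall between them. They also leave open whether a longer chain such as butyl, or a chain ending in an amine or a carboxylic acid, would extend the trend or reverse it.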